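The source may report more compounds than this note shows. Statements on the series, on what has been measured and on what is new or still open speak of the compounds shown alone.

Compound 1 `CC#C[C@H]1CN(S(=O)(=O)c2ccc(N)nc2)CCN1c1ccc(C(O)(CC#N)C(F)(F)F)cc1` and compound 2 `CC#C[C@H]1CN(S(=O)(=O)c2ccc(N)nc2)CCN1c1ccc(C(O)(C(F)(F)F)C(F)(F)F)cn1` are the two measured compounds here; compound 3 `CC#C[C@H]1CN(S(=O)(=O)c2ccc(N)nc2)CCN1c1ccc(S(=O)(=NC)C(F)(F)F)cc1` shares their core but has not yet been tested. In an assay on isolated protein for inhibition of glucokinase regulatory protein (Homo sapiens), read by AlphaScreen, with stated times of 20 min and 4 h (on this read-out lower numbers stand for stronger inhibition and higher numbers for weaker inhibition), compound 1 gives 28 nM, the higher of the two numbers, while compound 2 gives 10 nM, a difference beyond the usual scatter. Compound 3 differs from compound 1 by a group of 8 heavy atoms (2 carbon, 1 nitrogen, 1 oxygen, 3 fluorine, 1 sulfur; no ring) in place of a group of 9 heavy atoms (4 carbon, 1 nitrogen, 1 oxygen, 3 fluorine; no ring), on an aromatic carbon. No comparable single change has been measured, so the step from compound 1 to compound 3 is expected to be small, a 1.4-fold higher number from compound 1 to compound 3 (0.15 log units; within the scatter), with a slightly weaker result judged about as likely as a stronger one. Compound 3 is therefore expected to give 40 nM, within a range from 12 nM to 130 nM.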

Compound 3, half-maximal inhibitory concentration: 266 nM
For compound 3 the middle estimate is 6.7-fold (0.82 log units) below the measured one; measured number outside the range, above it.
By their numbers in this assay, from the lowest: compound 2; then compound 1; then compound 3.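

Size alone does not make groups interchangeable at this position, on an aromatic carbon para to a large group. In this assay, replacing a group of 9 heavy atoms with one of 8 gives a 9.5-fold higher number from compound 1 to compound 3 (0.98 log units; beyond the scatter), although both groups carry three fluorines and neither has a ring. No measurement available here explains this loss.

The change removes the hydrogen-bond donor and the triple bond and adds sulfur at once, so these compounds cannot separate their contributions. Going by these compounds, how an amine or a carboxylic acid would behave on this carbon also remains open.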